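The source may report more compounds than this note shows. Statements on the series, on what has been measured and on what is new or still open speak of the compounds shown alone.

Compound 1 `COc1cc(N)c(Cl)cc1NC(=O)C1CCN(Cc2ccc(Cl)cc2)CC1` gives 1.2 mg/kg in a functional assay on the whole organism for antagonist activity, with Mus musculus as the target; a higher number here means that more compound is needed for the effect, a lower number that less compound is needed. Compound 2 `COc1cc(N)c(Cl)cc1NC(=O)C1CCN(Cc2ccc([N+](=O)[O-])cc2)CC1` gives > 4 mg/kg, which is a limit of this assay. Compound 3 `COc1cc(N)c(Cl)cc1NC(=O)C1CCN(Cc2ccc(O)cc2)CC1` gives > 8 mg/kg, likewise a limit of this assay rather than a number.

Compound 3 therefore stands only at a limit, and the step that the two limits leave unreadable from compound 2 to compound 3 cannot be read because both ends sit at limits (the limit of > 4 mg/kg in this assay, at which 1 of the 3 values shown sits, (the limit of > 8 mg/kg in this assay, at which 1 of the 3 values shown sits)). Compound 4 `COc1cc(N)c(Cl)cc1NC(=O)C1CCN(Cc2ccc(OCc3ccccc3)cc2)CC1` differs from compound 3 by benzyl in place of hydrogen on an oxygen on an aromatic ring. For the measured compounds named here, no measured step exchanges hydrogen for benzyl on this oxygen; the measured steps of an at least 6.6-fold higher number from compound 1 to compound 3 (0.82 log units; beyond the scatter) and an at least 3.3-fold higher number from compound 1 to compound 2 (0.52 log units; beyond the scatter) both concern replacement of the chloro and do not anchor this change. With compound 3 known only as a limit, neither direction nor size of the step can be set from the data, so any number for compound 4 is a loose estimate. Compound 4 is expected at 4 mg/kg (range 1 mg/kg to 16 mg/kg). The step of an at least 2.0-fold lower number from compound 3 to compound 4 (0.30 log units; that floor lies within the scatter) is accordingly an expectation only, with a real chance that compound 4 again returns only a limit.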

Compound 4, dose for half-maximal effect: > 4 mg/kg
Compound 4: a limit, no number (the forecaster's own chance of this, stated with the estimate: 45%); the middle value lies on the limit itself.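

Benzyloxy now joins nitro and hydroxy as a replacement for chloro on this aromatic carbon that moves the number up in this assay: an at least 3.3-fold higher number from compound 1 to compound 4 (0.52 log units; beyond the scatter). Putting benzyl on the hydroxy oxygen does not bring back a number, so among the groups shown at this place only chloro, in compound 1, gives one. The steps among compound 2, compound 3 and compound 4 cannot be read, as all three values are limits.

Going by these compounds, how far these three lie from compound 1 stays open. So does whether bromo, an amine or a carboxylic acid at this place would return a number.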